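The source may report more compounds than this note shows. Statements on the series, on what has been measured and on what is new or still open speak of the compounds shown alone.

Working notes on the series. In a functional assay on HT-29 cells (Homo sapiens) for antiproliferative activity, read by MTT assay, with a stated time of 48 h (on this read-out lower numbers stand for stronger inhibition and higher numbers for weaker inhibition), compound 1 `Oc1ccc2cc1Oc1ccc(cc1)CCc1cccc(O)c1Oc1ccc(cc1)CC2` gives 7570 nM. Compound 2 `Oc1ccc2cc1Oc1ccc(cc1)CCc1cccc(O)c1Oc1ccc(cc1O)CC2` carries hydroxy in place of hydrogen on an aromatic carbon relative to compound 1, and in this assay compound 2 gives 17000 nM, so a 2.2-fold higher number from compound 1 to compound 2 (0.35 log units; beyond the scatter). Compound 3 `Oc1ccc2cc1Oc1ccc(cc1)CCc1ccc(O)c(c1)Oc1ccc(cc1)CC2` has the same atoms as compound 1 joined differently, and the difference between the two cores is not broken down here. In this assay compound 3 gives 11500 nM, a number that lies within the scatter of both compound 2 and compound 1. Compound 4 `Oc1ccc2cc1Oc1ccc(cc1)CCc1ccc(O)c(c1)Oc1ccc(cc1O)CC2` is not yet measured; against compound 3 it carries hydroxy in place of hydrogen on an aromatic carbon, the same change as that made between compound 1 and compound 2, so this change occurs two times among these compounds. Within the data shown here, an expected step of a 2.1-fold higher number from compound 3 to compound 4 (0.32 log units; beyond the scatter) is taken, and it rests on the earlier single observation, a 2.2-fold higher number from compound 1 to compound 2 (0.35 log units; beyond the scatter), with only one precedent to lean on. Compound 4 is therefore expected to give about 24000 nM, with a plausible range from 11000 nM to 55000 nM.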

Compound 4, half-maximal inhibitory concentration: 14900 nM
Compound 4: middle estimate off by 1.6-fold (0.21 log units), on the high side; the range from low to high includes it.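

In this assay, hydroxy in place of hydrogen on an aromatic carbon gives a 1.3-fold higher number from compound 3 to compound 4 (0.11 log units; within the scatter), and set beside the earlier step on the core of compound 1, the two steps do not differ beyond the scatter: the same change on two cores in this assay, a 2.2-fold higher number (0.35 log units; beyond the scatter) from compound 1 to compound 2 and a 1.3-fold higher number (0.11 log units; within the scatter) from compound 3 to compound 4, 1.7-fold (0.24 log units) apart, within the scatter of two such steps. On these two cores, then, the change carries over without a demonstrable dependence on the core. This does not show that the step has the same size on both, as one step lies beyond the scatter and the other within it, and two pairs say nothing about any further core.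

The compounds shown leave open whether a methoxy group or an amine in the same place would give a similar step on both cores. Also open, on these data alone, is whether hydroxy on other aromatic carbons would do so.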